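The compounds below may be only part of what the source reports. "The series", "measured", "known", "first", "only" and "open" are said of these compounds alone.

Measured so far in a functional assay on MCF7 cells (Homo sapiens) for inhibition, read by MTT assay, with a stated time of 72 h; on this read-out higher numbers stand for weaker inhibition and lower numbers for stronger inhibition:
- compound 1 `O=C(Nc1ccccc1)C1CCN(C/C=C/c2ccccc2)CC1`: 60200 nM
- compound 2 `CCc1ccc(NC(=O)C2CCN(C/C=C/c3ccccc3)CC2)cc1`: 20000 nM
- compound 3 `O=C(Nc1cccc(C(F)(F)F)c1)C1CCN(C/C=C/c2ccccc2)CC1`: 16100 nM

Compound 2 lies within the usual scatter of compound 3, and both sit clearly under compound 1. Compound 4 `O=C(Nc1cccc(F)c1)C1CCN(C/C=C/c2ccccc2)CC1` is still unmeasured, and it differs from compound 2 in one group: 3-fluorophenyl in place of 4-ethylphenyl on an amide-type nitrogen. Within the data shown here, two measured steps bear on this change, a 3.0-fold lower number from compound 1 to compound 2 (0.48 log units; beyond the scatter) and a 3.7-fold lower number from compound 1 to compound 3 (0.57 log units; beyond the scatter). Both are modest, and each adds a group to the aromatic ring of compound 1. Neither adds fluorine, so they guide only loosely. Compound 4 also carries a group on that ring, so it is expected to stay near compound 2. The expected step is a 1.4-fold higher number from compound 2 to compound 4 (0.15 log units; within the scatter), which would stay within the scatter. In this assay the estimated value for compound 4 is 28000 nM, expected to fall between 11000 nM and 65000 nM.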

Compound 4, half-maximal inhibitory concentration: 33000 nM
Estimate against measurement, compound 4: 1.2-fold (0.07 log units) below; the measured number falls inside the stated range.
By their numbers in this assay, from the lowest: compounds 3, 2, 4 and 1 (each within the scatter of the next, the first and the last beyond it).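

Unlike ethyl and trifluoromethyl, the fluoro group cannot be told apart from hydrogen in this assay with a 1.8-fold lower number from compound 1 to compound 4 (0.26 log units; within the scatter) as its step. Putting 3-fluorophenyl in place of 4-ethylphenyl gives a 1.7-fold higher number from compound 2 to compound 4 (0.22 log units; within the scatter) and so shows no clear change, while fluoro and trifluoromethyl do separate narrowly, with a 2.0-fold higher number from compound 3 to compound 4 (0.31 log units; beyond the scatter) as a modest step. Nothing measured here explains these steps. Still open, from the compounds shown here alone, is what an amine or a carboxylic acid on this aromatic ring would give, and what a chain longer than ethyl would do.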